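The source may report more compounds than this note shows. Statements on the series, on what has been measured and on what is new or still open speak of the compounds shown alone.

Of the compounds shown here, two have so far been measured in a physicochemical assay for lipophilicity, at pH 7.4; a higher number here means a more lipophilic compound, a lower number a more polar compound. Compound 1, `CC(C)CN(c1ccc(C#N)cc1)S(=O)(=O)c1ccc2c(c1)C(=O)CC(C1CCOCC1)O2`, gives 3.16. Compound 2, `CCc1ccc(N(C2CCC2)S(=O)(=O)c2ccc3c(c2)C(=O)CC(C2CCOCC2)O3)cc1`, gives 3.78. Of these two numbers, compound 1 stands lowest, and compound 2 lies above it by more than the usual scatter of the measurement. Compound 3, `CC(C)CN(c1ccc(F)cc1)S(=O)(=O)c1ccc2c(c1)C(=O)CC(C1CCOCC1)O2`, has not yet been measured. It keeps the core of compound 1 and differs in a single place: fluoro in place of cyano on an aromatic carbon. Going by the values given here, no pair of measured compounds differs in exactly this way, so there is no measured step to set against this change. Nevertheless, in this assay a step upward that is expected to exceed the scatter, of about a number 0.64 log units higher from compound 1 to compound 3 (beyond the scatter), seems likely. On that basis compound 3 is estimated at 3.8 in this assay, with a probable range from 3.4 to 4.3.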

Compound 3, distribution coefficient: 3.48
Compound 3: the middle estimate sits 0.32 log units above what was measured; measured number inside the range.
By their numbers in this assay, from the lowest: compound 1; then compounds 3 and 2 (each within the scatter of the next).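

Going by these compounds alone, until now no two measured compounds differed in only one place, so this spot on the aromatic ring, para to a large group, had no measured step of its own. In this assay, fluoro in place of cyano now gives a number 0.32 log units higher from compound 1 to compound 3 (beyond the scatter), a modest change that is still large enough to read. The exchange leaves one heavy atom fewer and one hydrogen-bond acceptor fewer, but nothing available here shows what drives the change in number.

The compounds shown do not tell how an amine, a carboxylic acid or a methoxy group at this same place would read in this assay. They also leave open whether the same exchange would give a similar step with a different group on the sulfonamide nitrogen.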